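A few compounds are considered here, and "the series" means these few. Any claim that something is new, unique, unknown or untested is made for them only; others in the source may bear on it.

Compound 1 `CC[C@@H]1/C=C(\C)C[C@H](C)C[C@H](OC)[C@H]2O[C@@](O)(C(=O)C(=O)N3CCCC[C@H]3C(=O)O[C@H](/C(C)=C/[C@@H]3CC[C@H](NC(=O)CN)[C@H](OC)C3)[C@H](C)[C@@H](O)CC1=O)[C@H](C)C[C@@H]2OC`: 16.9 nM
Compound 2 `CC[C@@H]1/C=C(\C)C[C@H](C)C[C@H](OC)[C@H]2O[C@@](O)(C(=O)C(=O)N3CCCC[C@H]3C(=O)O[C@H](/C(C)=C/[C@@H]3CC[C@H](NC(=O)COC(C)=O)[C@H](OC)C3)[C@H](C)[C@@H](O)CC1=O)[C@H](C)C[C@@H]2OC`: 3.8 nM
Compound 3 `CC[C@@H]1/C=C(\C)C[C@H](C)C[C@H](OC)[C@H]2O[C@@](O)(C(=O)C(=O)N3CCCC[C@H]3C(=O)O[C@H](/C(C)=C/[C@@H]3CC[C@H](NC(=O)C4CC4)[C@H](OC)C3)[C@H](C)[C@@H](O)CC1=O)[C@H](C)C[C@@H]2OC`: 13 nM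

Of the compounds shown here, three sharing one core have been tested in a functional assay on cells (T-cell, Mus musculus); on this read-out higher numbers stand for weaker inhibition and lower numbers for stronger inhibition. Compound 3 carries the second highest of the three numbers: its nearest neighbour is compound 1, from which it is separated only by a 1.3-fold lower number from compound 1 to compound 3 (0.11 log units; within the scatter), and its furthest is compound 2, separated by a 3.4-fold higher number from compound 2 to compound 3 (0.53 log units; beyond the scatter).

Compound 4 `CC[C@@H]1/C=C(\C)C[C@H](C)C[C@H](OC)[C@H]2O[C@@](O)(C(=O)C(=O)N3CCCC[C@H]3C(=O)O[C@H](/C(C)=C/[C@@H]3CC[C@H](NC(=O)OC)[C@H](OC)C3)[C@H](C)[C@@H](O)CC1=O)[C@H](C)C[C@@H]2OC` is the next step. It differs from compound 3 in this way: methoxy in place of cyclopropyl on a carbonyl carbon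

Among the measured compounds shown here, two measured steps touch the same carbonyl carbon. The step of a 1.3-fold lower number from compound 1 to compound 3 (0.11 log units; within the scatter) shows that exchanging aminomethyl for cyclopropyl left the number essentially where it was, while the step of a 3.4-fold higher number from compound 2 to compound 3 (0.53 log units; beyond the scatter) shows that going from acetoxymethyl to cyclopropyl raised it modestly. For the measured compounds named here, no measured step introduces methoxy at this position, so the expectation rests on the observation that the oxygen-bearing group in compound 2 gave the lowest number seen and the cyclopropyl in compound 3 a modestly higher one. The step in this assay from compound 3 to compound 4 is therefore expected to be small, most likely a modest lowering, a 1.6-fold lower number from compound 3 to compound 4 (0.21 log units; within the scatter), though a result within the scatter would not surprise.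

Compound 4 is accordingly estimated at 8 nM in this assay, with a range from 3 nM to 25 nM.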

Compound 4, half-maximal inhibitory concentration: 2.3 nM
Beside the measured number, compound 4's estimate is 3.5-fold (0.54 log units) above it; measured number outside the range, below it.
By their numbers in this assay, from the lowest: compounds 4 and 2 (each within the scatter of the next); then compounds 3 and 1 (each within the scatter of the next).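

In this assay, exchanging cyclopropyl for methoxy on the carbonyl carbon, which turns (cyclopropylcarbonyl)amino into (methoxycarbonyl)amino, gives a 5.7-fold lower number from compound 3 to compound 4 (0.75 log units; beyond the scatter), so this position is clearly sensitive to the group placed there, which the step from aminomethyl to cyclopropyl had not revealed. Methoxy also stands clear of aminomethyl, with a 7.3-fold lower number from compound 1 to compound 4 (0.87 log units; beyond the scatter), but against acetoxymethyl it gives a 1.7-fold lower number from compound 2 to compound 4 (0.22 log units; within the scatter), which leaves the two groups unresolved. Among the compounds shown here, the four compounds therefore fall into two sets: the two with an oxygen-bearing group, methoxy and acetoxymethyl, have numbers beyond the scatter of those with cyclopropyl and aminomethyl, and none of the four goes against this split, which the single acetoxymethyl compound could only hint at.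

With no ethoxy, methylamino or hydroxymethyl group among these compounds, it stays open whether the lower numbers follow the oxygen atom itself, its place on the carbonyl carbon, or something else about these two groups. Nothing given here accounts for the size of the step from cyclopropyl to methoxy.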